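The compounds below may be only part of what the source reports. "The series", "measured", "known", "first", "only" and "open" are said of these compounds alone.

Four compounds share one core and differ only in the substitution of a benzyl group attached to it. Compound 1 `CCOC(=O)C1(Cc2ccccc2)CN(c2ccccc2)Cc2nnn(Cc3ccccc3)c21` carries the unsubstituted benzyl. In an ADME assay on HEL cells (Homo sapiens) for cytotoxicity, read by microscopy, with a stated time of 3 days (on this read-out higher numbers stand for lower toxicity in this test and lower numbers for higher toxicity in this test), compound 1 gives >= 20000 nM, which is a limit of the assay and not a measured number. Compound 2 `CCOC(=O)C1(Cc2ccccc2)CN(c2ccccc2)Cc2nnn(Cc3cccc(F)c3)c21` has fluoro in place of hydrogen on an aromatic carbon of that benzyl. In this assay compound 2 gives >= 100000 nM, again a limit. Compound 3 `CCOC(=O)C1(Cc2ccccc2)CN(c2ccccc2)Cc2nnn(Cc3cccc(Cl)c3)c21` carries a 3-chlorobenzyl. In this assay compound 3 gives > 100000 nM, also a limit, so compound 3 stands at a limit, as do the other two values shown. Because all three values sit at limits the limit of > 100000 nM in this assay, at which 1 of the 3 values shown sits, the limit of >= 100000 nM in this assay, at which 1 of the 3 values shown sits (the limit of >= 20000 nM in this assay, at which 1 of the 3 values shown sits), the steps a step that the two limits leave unreadable from compound 1 to compound 2, a step that the two limits leave unreadable from compound 1 to compound 3 and a step that the two limits leave unreadable from compound 2 to compound 3 cannot be sized.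

Compound 4 `CCOC(=O)C1(Cc2ccccc2)CN(c2ccccc2)Cc2nnn(Cc3ccc(Cl)c(Cl)c3)c21` is not yet measured. It differs from compound 3 by chloro in place of hydrogen on an aromatic carbon, turning 3-chlorobenzyl into 3,4-dichlorobenzyl. Every measured step among these compounds is unreadable, so the expectation for this step rests only on the three limits shown. The step of a number no higher from compound 3 to compound 4 (the limit leaves the size open) is expected to stay within the scatter. Compound 4 is therefore estimated at 100000 nM, in a range from 20000 nM to 200000 nM, most probably again reported only as a limit.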

Compound 4, minimum cytotoxic concentration: > 100000 nM
Compound 4 was reported as a limit; the forecaster's own chance of this, stated with the estimate: 85%; the middle value sits exactly at the limit.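

In this assay compound 4 gives > 100000 nM, which is a limit of the assay and not a number, so its steps from compound 1, compound 2 and compound 3 cannot be read. The compounds shown leave open how much, if at all, any of these changes on the benzyl group alters toxicity to these cells.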